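Chain branching on the amine of compound 2

This account rests on a few compounds, and the source may have more. Where it says the series, first, only, none or still open, it means among the compounds named here.

Compound 1 `Nc1ncc(-c2cccc(Cl)c2)c(-c2ccccc2)n1` is reported in an assay on CHO cells for displacement of a labelled ligand from adenosine receptor A1 (Homo sapiens), read by scintillation counting, with a stated time of 1 h, tested at 1 uM (a higher number here means more inhibition at the concentration tested (going by the name of the read-out), a lower number less inhibition), only as a limit of the assay, > 80%. Among the compounds with values here, compound 2 `CCCCNc1ncc(-c2cccc(Cl)c2)c(-c2ccccc2)n1` gives 56% in this assay, the only plain number in the set. Within the data shown here, the sole measured step is a number at least 24 percentage points lower from compound 1 to compound 2 (beyond the scatter), which concerns the amine substituent. Compound 3 `CC(C)CCNc1ncc(-c2cccc(Cl)c2)c(-c2ccccc2)n1` differs from compound 2 by methyl in place of hydrogen on a saturated chain carbon bound to two saturated chain carbons. Among the measured compounds shown here, no measured step addresses branching within the chain, so in this assay a change within the scatter is expected, a number 4 percentage points lower from compound 2 to compound 3 (within the scatter). Compound 3 is therefore estimated at 52% in this assay, within 32% to 72%.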

Compound 3, a percentage reported as inhibition, at one concentration (the size of the read-out at that concentration, not a potency): 39%
Compound 3: the middle estimate sits 13 percentage points above what was measured; measured number inside the range.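

In this assay, the change at the saturated chain carbon bound to two saturated chain carbons is not silent: butyl to isopentyl gives a number 17 percentage points lower from compound 2 to compound 3 (beyond the scatter). Substitution on the amine thus matters beyond the first chain carbon, and the whole isopentyl group gives a number at least 41 percentage points lower from compound 1 to compound 3 (beyond the scatter). That step is only a bound, since compound 1 is reported as a limit of the assay: the limit of > 80% in this assay, at which 1 of the 3 values shown sits.

Open, going by these compounds, is whether a shorter chain such as ethyl, or a cyclopentyl ring on the same nitrogen, reads nearer compound 1 or compound 3. Also open, on these data alone, is how a hydroxyl on the chain would read in this assay.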